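A few compounds are considered here, and "the series" means these few. Any claim that something is new, unique, unknown or untested is made for them only; others in the source may bear on it.

Compound 1 `CC(C)(C)NC(=O)N1CC1C#N` is a small urea in which the shared core carries a tert-butyl group on the urea nitrogen. For the measured compounds named here, in a functional assay on RPMI-8226 cells (Homo sapiens) for inhibition (a lower number here means a stronger inhibitor, a higher number a weaker inhibitor), compound 1 gives 216000 nM, the highest of the three numbers measured so far. Compound 2 `N#CC1CN1C(=O)Nc1ccccc1` gives 8000 nM in this assay, and compound 3 `N#CC1CN1C(=O)Nc1cccc2ccccc12` gives 8900 nM; both of these values sit well beyond the usual scatter from the value of compound 1. Compound 4 `CCNC(=O)N1CC1C#N` has not yet been measured. It differs from compound 1 in one place: ethyl in place of tert-butyl on an amide-type nitrogen. Going by the values given here, no measured pair shows this same change, so the step is only an expectation: it is expected to be a 1.4-fold lower number from compound 1 to compound 4 (0.16 log units; within the scatter), not beyond the scatter. Compound 4 is therefore estimated at 150000 nM, within a range from 40000 nM to 500000 nM.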

Compound 4, half-maximal inhibitory concentration: 26000 nM
Compound 4: middle estimate off by 5.8-fold (0.76 log units), on the high side; the measured number lies below the stated range.
By their numbers in this assay, from the lowest: compounds 2 and 3 (each within the scatter of the next); then compound 4; then compound 1.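

On the amide-type nitrogen, ethyl in place of tert-butyl gives an 8.3-fold lower number from compound 1 to compound 4 (0.92 log units; beyond the scatter), the first measured sign that the group at this position matters in this assay. The group with fewer carbons goes with the stronger inhibition here, but one pair sets no trend. No measurement shown explains this step. A methyl group at this nitrogen could show whether the number keeps falling as the group shrinks. A longer chain, such as n-butyl, could show whether branching or chain length tracks with the change.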